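A few compounds are considered here, and "the series" means these few. Any claim that something is new, unique, unknown or untested is made for them only; others in the source may bear on it.

For the measured compounds named here, in a functional assay on HeLa cells (Homo sapiens) for antiproliferative activity, with a stated time of 48 h (a lower number here means a stronger inhibitor, a higher number a weaker inhibitor), compound 1 `Nc1ccc(/C=C/C(=O)c2ccccc2)cc1` gives 36000 nM and compound 2 `Nc1ccc(/C=C/C(=O)c2ccc(Cl)cc2)cc1` gives 43000 nM, so compound 2 stands level with compound 1 on the only two numbers available. Compound 3 `Nc1ccc(/C=C/C(=O)c2ccc(Br)cc2)cc1` differs from compound 2 by bromo in place of chloro on an aromatic carbon, which is bromo in place of chloro on an aromatic carbon. Going by the values given here, the one measured step that bears on this is chloro in place of hydrogen, a 1.2-fold higher number from compound 1 to compound 2 (0.08 log units; within the scatter). With that step so small, no change beyond the scatter is expected in this assay. The expected step is a 1.0-fold lower number from compound 2 to compound 3 (0.01 log units; within the scatter). For compound 3 the estimated value is 42000 nM, with an expected range of 20000 nM to 85000 nM.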

Compound 3, half-maximal inhibitory concentration: 49000 nM
For compound 3 the middle estimate is 1.2-fold (0.07 log units) below the measured one, within the range that was stated.
By their numbers in this assay, from the lowest: compounds 1, 2 and 3 (each within the scatter of the next).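

In this assay, bromo in place of chloro gives a 1.1-fold higher number from compound 2 to compound 3 (0.06 log units; within the scatter), and bromo in place of hydrogen gives a 1.4-fold higher number from compound 1 to compound 3 (0.13 log units; within the scatter). Even across the wider comparison with hydrogen, then, the step stays within the scatter, so hydrogen, chloro and bromo on this aromatic carbon, para to a large group, cannot be told apart. No measurement shown here accounts for this result.

Still open, on these data alone, is whether any group at this place can move the number beyond the scatter. A carboxylic acid, a nitrile or a methoxy group could answer that.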